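Amino for phenyl on the shared core of two propargyloxy biaryls

The source may report more compounds than this note shows. Statements on the series, on what has been measured and on what is new or still open speak of the compounds shown alone.

Compounds measured so far:
compound 1, `C#CCOc1ccc(-c2cc(-c3ccc(OCC#C)cc3)nc(C)n2)cc1`, giving 7830 nM in an assay on BTI-TN-5B1-4 cells for inhibition of Amine oxidase [flavin-containing] B (Homo sapiens), read by fluorescence and Amplex Red, using microsomes, with a stated time of 30 min; on this read-out higher numbers stand for weaker inhibition and lower numbers for stronger inhibition;
compound 2, `C#CCOc1ccc(-c2cc(-c3ccc(OCC#C)cc3)nc(-c3ccccc3)n2)cc1`, giving 12300 nM in this assay.

Compound 2 shows the highest of the two numbers in this assay, but its nearest neighbour, compound 1, lies within the scatter of it, so the two cannot be told apart. Among the measured compounds shown here, the only measured step, a 1.6-fold higher number from compound 1 to compound 2 (0.20 log units; within the scatter), shows that exchanging methyl for phenyl at that position of the core did nothing beyond the scatter.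

Compound 3, `C#CCOc1ccc(-c2cc(-c3ccc(OCC#C)cc3)nc(N)n2)cc1`, differs from compound 2 by amino in place of phenyl on an aromatic carbon. For the measured compounds named here, no measured step involves an amino group, so the step from compound 2 to compound 3 has no direct precedent; the one step that bears on it shows the position tolerating a large change without movement. On that basis the number for compound 3 is expected to stay close to compound 2, with no step beyond the scatter in either direction, which is what a 1.2-fold lower number from compound 2 to compound 3 (0.09 log units; within the scatter) expresses. Compound 3 is therefore estimated at 10000 nM, within a range from 3000 nM to 40000 nM.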

Compound 3, half-maximal inhibitory concentration: 3300 nM
Beside the measured number, compound 3's estimate is 3.0-fold (0.48 log units) above it, and the stated range covers the measured number.
By their numbers in this assay, from the lowest: compound 3; then compounds 1 and 2 (each within the scatter of the next).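

The position between two ring nitrogen atoms, which had shown no movement beyond the scatter when phenyl took the place of methyl, does respond to the group placed there: in this assay amino in place of phenyl gives a 3.7-fold lower number from compound 2 to compound 3 (0.57 log units; beyond the scatter) and amino in place of methyl gives a 2.4-fold lower number from compound 1 to compound 3 (0.38 log units; beyond the scatter) as its counterpart. Both steps are modest but lie beyond the scatter, so compound 3 stands apart from compound 1 and compound 2, which remain within the scatter of each other, and the tolerance seen in the earlier pair does not extend to every group at this position. The change from compound 2 to compound 3 replaces a six-membered aromatic ring of carbon only with a single nitrogen heavy atom that counts as a hydrogen-bond donor and acceptor, and one compound cannot separate these differences from one another.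

On these data alone, it remains open whether the lower number belongs to amino alone or would persist with a methylamino, a dimethylamino or a hydroxyl group at this position. No evidence is at hand that accounts for the response of this position to amino.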